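A few compounds are considered here, and "the series" means these few. Any claim that something is new, unique, unknown or untested is made for them only; others in the source may bear on it.

Going by the values given here, compound 2 `O=[N+]([O-])c1cccc(C2=NC(c3ccc(F)cc3)(c3ccc(F)cc3)CN2)c1` stands at the lower of the two numbers measured so far, giving 4.3 nM in an assay on LM cells for displacement of a labelled ligand from Neuropeptide Y receptor type 5 (Homo sapiens); on this read-out lower numbers stand for stronger inhibition and higher numbers for weaker inhibition. Compound 1 `Fc1ccc(C2(c3ccc(F)cc3)CNC(c3cccc(Cl)c3)=N2)cc1` sits close by, giving 5.4 nM in this assay. Among the compounds with values here, the only measured step, a 1.3-fold lower number from compound 1 to compound 2 (0.10 log units; within the scatter), put nitro in place of chloro on the ring that sits on the carbon with a double bond to nitrogen, and it stayed within the scatter. Compound 3 `N#Cc1cccc(C2=NC(c3ccc(F)cc3)(c3ccc(F)cc3)CN2)n1` differs from compound 2 at that same place: 6-cyanopyridin-2-yl in place of 3-nitrophenyl on a carbon with a double bond to nitrogen. Within the data shown here, the one step that bears on this position was small, but it exchanged only a substituent, whereas here the whole ring is exchanged, so the measured data give no firm direction. The account therefore expects no step beyond the scatter, a 1.9-fold higher number from compound 2 to compound 3 (0.27 log units; within the scatter), with a wide range, and estimates compound 3 at 8 nM (from 2 nM to 40 nM).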

Compound 3, half-maximal inhibitory concentration: 39 nM
Beside the measured number, compound 3's estimate is 4.9-fold (0.69 log units) below it; measured number inside the range.
By their numbers in this assay, from the lowest: compounds 2 and 1 (each within the scatter of the next); then compound 3.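

In this assay, the place on the carbon with a double bond to nitrogen responds to a change of the whole ring: 6-cyanopyridin-2-yl in place of 3-nitrophenyl gives a 9.1-fold higher number from compound 2 to compound 3 (0.96 log units; beyond the scatter), and the same group in place of 3-chlorophenyl gives a 7.2-fold higher number from compound 1 to compound 3 (0.86 log units; beyond the scatter). Going by these compounds alone, the earlier exchange of chloro for nitro on the phenyl ring stayed within the scatter, so these are the first steps at this position that lie beyond it. Nothing at hand accounts for the size of these steps.

From the compounds shown here alone, the exchange alters the ring and its substituent together, so whether the ring nitrogen or the nitrile carries the step stays open; a 3-cyanophenyl group or a plain pyridin-2-yl group would separate the two. Going by these compounds, how a phenyl ring bearing an amine or a carboxylic acid would read at this position also remains open.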